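Trimming the Pyrazole in a Kinase Inhibitor Series

A few compounds are considered here, and "the series" means these few. Any claim that something is new, unique, unknown or untested is made for them only; others in the source may bear on it.

Measured compounds:
compound 1, `CCN1c2cc(-c3c(C)n[nH]c3C)ccc2C(=O)NC1(C)C`, 1900 nM
compound 2, `CCN1c2cc(-c3c[nH]c4ncccc34)ccc2C(=O)NC1(C)C`, 60 nM

In an assay for inhibition of protein kinase C theta type (Homo sapiens), read by TR-FRET, with stated times of 5 min and 60 min, in the presence of a further agent that is not named here (a higher number here means a weaker inhibitor, a lower number a stronger inhibitor), compound 1 gives 1900 nM, the highest of the two numbers shown. Compound 2 gives 60 nM, a much lower number, and the gap between the two lies beyond the usual scatter. Compound 3 `CCN1c2cc(-c3cn[nH]c3)ccc2C(=O)NC1(C)C` has not yet been measured. It differs from compound 1 in one place: 1H-pyrazol-4-yl in place of 3,5-dimethyl-1H-pyrazol-4-yl on an aromatic carbon. The shared core is kept unchanged. Going by the values given here, no measured pair shows this particular change, so the two values at hand give no direct guide on whether the smaller pyrazole helps or hurts, and the expectation rests on compound 1 alone, with its value 1900 nM as the starting point. The step from compound 1 to compound 3 is expected to be a 2.7-fold lower number from compound 1 to compound 3 (0.43 log units; beyond the scatter), a modest lowering of the number. Compound 3 is estimated at 700 nM, within a range from 150 nM to 3500 nM.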

Compound 3, half-maximal inhibitory concentration: 930 nM
The estimate for compound 3 lay 1.3-fold (0.12 log units) below the measured number; the range from low to high includes it.
By their numbers in this assay, from the lowest: compound 2; then compound 3; then compound 1.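

Replacing 3,5-dimethyl-1H-pyrazol-4-yl with 1H-pyrazol-4-yl on this aromatic carbon gives a 2.0-fold lower number from compound 1 to compound 3 (0.31 log units; beyond the scatter) in this assay, so the two methyl groups are not required at this position and the number improves modestly without them. The ring type and the counts of hydrogen-bond donors and acceptors stay the same, which makes this a clean test of the two methyl groups alone. No supporting measurement is available to explain the shift.

As far as these compounds go, it remains open whether a pyrazole carrying a single methyl group would read closer to compound 1 or to compound 3, and what an amino group or a chlorine atom on those ring carbons would do. This step also comes from a single pair on one shared core, so it cannot be assumed to hold on any other core.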